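This account rests on a few compounds, and the source may have more. Where it says the series, first, only, none or still open, it means among the compounds named here.

Values so far in a physicochemical assay for acid dissociation:

- compound 1 `C=C(C)COC[n+]1ccn(C)c1/C=N/O` gives 7.99
- compound 2 `C=CCCOC[n+]1ccn(C)c1/C=N/O` gives 7.97

For the measured compounds named here, only these two numbers exist, and the single step joining them is a number 0.02 log units lower from compound 1 to compound 2 (within the scatter), so compound 1 cannot be set apart from its one neighbour.

Compound 3 `C=C(C)CC(OC[n+]1ccn(C)c1/C=N/O)C(=C)C` keeps the core of compound 1 and carries an extra branch. The change is 2-methylprop-2-en-1-yl in place of hydrogen on a saturated chain carbon bound to a double-bonded chain carbon and an oxygen on a saturated carbon.

Going by the values given here, one measured step bears on this, and only loosely. Compound 2 has allyl in place of 1-methylethenyl on a saturated chain carbon bound to an oxygen on a saturated carbon, and that edit of the same chain gave a number 0.02 log units lower from compound 1 to compound 2 (within the scatter) as its result. It swaps one group for another rather than adding a branch, so it is a thin guide. No shift beyond the scatter is therefore expected in this assay, and the estimated step is a number 0.01 log units lower from compound 1 to compound 3 (within the scatter) as a working figure. For compound 3 the expected value is 7.98, with an estimated range from 7.75 to 8.2.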

Compound 3, acid dissociation constant: 7.91
Beside the measured number, compound 3's estimate is 0.07 log units above it; low and high end bracket the measured number.
By their numbers in this assay, from the lowest: compounds 3, 2 and 1 (each within the scatter of the next).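

In this assay, putting 2-methylprop-2-en-1-yl in place of hydrogen on a saturated chain carbon bound to a double-bonded chain carbon and an oxygen on a saturated carbon gives a number 0.08 log units lower from compound 1 to compound 3 (within the scatter) as its result. For the compounds shown here, the only earlier step on this chain swapped one group for another, whereas this one adds a whole branch of 4 heavy atoms, all carbon, with one double bond, and the read-out still cannot be told apart from that of the compound without the branch. No measurement is at hand that could account for the size of this step.

This is one added branch at one carbon, and it is a hydrocarbon, so the result cannot be extended to other kinds of group. Going by these compounds, whether an amine or a carboxylic acid at this same carbon, or a longer chain with a phenyl ring at its end, would move the number beyond the scatter stays open.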